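A few compounds are considered here, and "the series" means these few. Any claim that something is new, unique, unknown or untested is made for them only; others in the source may bear on it.

Measured compounds:
compound 1 `CC(C)(C)c1cc(N)c2cc(NC(=O)/C=C/c3ccc(C(F)(F)F)cc3)ccc2n1`: 29 nM
compound 2 `CCCCc1ccc(/C=C/C(=O)Nc2ccc3nc(CCC)cc(N)c3c2)cc1`: 740 nM
compound 3 `CCCc1cc(N)c2cc(NC(=O)/C=C/c3ccc(Cl)cc3)ccc2n1`: 96 nM

In a functional assay on HEK293 cells for activation of melanin-concentrating hormone receptor 1 (Homo sapiens), read by inositol phosphate accumulation (on this read-out lower numbers stand for an effect already at smaller amounts and higher numbers for an effect only at larger amounts of compound), compound 1 gives the lowest number of the three; compound 3 gives 96 nM and compound 2 gives 740 nM. Going by the values given here, the only single-point step, a 7.7-fold lower number from compound 2 to compound 3 (0.89 log units; beyond the scatter), concerns the substituent on the aromatic carbon and does not bear on the change now in question. Compound 4 `CC(C)c1cc(N)c2cc(NC(=O)/C=C/c3ccc(C(F)(F)F)cc3)ccc2n1` differs from compound 1 by hydrogen in place of methyl on a saturated chain carbon bound to an aromatic carbon and two saturated chain carbons. Among the compounds with values here, no measured pair isolates this change: compounds 2 and 3 carry propyl where compound 1 carries tert-butyl, but both also differ from compound 1 elsewhere, so their values cannot be split. Only a small shift is expected in this assay, a 1.6-fold higher number from compound 1 to compound 4 (0.19 log units; within the scatter). Compound 4 is therefore estimated at 45 nM, range 15 nM to 130 nM.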

Compound 4, half-maximal effective concentration: 160 nM
Estimate against measurement, compound 4: 3.6-fold (0.55 log units) below; the measured number lies above the stated range.
By their numbers in this assay, from the lowest: compound 1; then compounds 3 and 4 (each within the scatter of the next); then compound 2.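

In this assay the change from tert-butyl to isopropyl gives a 5.5-fold higher number from compound 1 to compound 4 (0.74 log units; beyond the scatter), so removing a single methyl from this saturated chain carbon moves the number beyond the scatter. Going by these compounds alone, this is the first pair to isolate the group at this position, and the position proves sensitive to the change. Nothing measured here accounts for the step. From the compounds shown here alone, whether a cyclopropyl ring, a longer chain or an amine at this position would restore the number of compound 1 remains open. Propyl cannot be placed in this comparison, since compound 2 and compound 3 also differ elsewhere.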